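Pyrazine hydrazones: isopropyl in place of phenyl at compound 1

This account rests on a few compounds, and the source may have more. Where it says the series, first, only, none or still open, it means among the compounds named here.

Measured so far:
compound 1 `O=C(N/N=C/c1ccc(-c2ccccc2)cc1)c1cnccn1` — 14.4%
compound 2 `O=C(N/N=C/c1ccc(O)cc1)c1cnccn1` — 43.1%
compound 3 `COc1ccc(/C=N/NC(=O)c2cnccn2)cc1OC` — 51.3%

Three members of the series carry a number in a functional assay on the whole organism (strain Swiss) for inhibition, with Mus musculus as the target, with stated times of 40 min and 6 h, at a dose of 100 mg/kg by the oral route; a lower number here means less inhibition, a higher number more inhibition at the dose given (going by the name of the read-out). Compound 1 gives 14.4%, the lowest of the three; compound 2 is nearest to it with 43.1%, and compound 3 is furthest with 51.3%. Both gaps from compound 1 lie beyond the scatter.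

Compound 4 `CC(C)c1ccc(/C=N/NC(=O)c2cnccn2)cc1` is the next member to be measured. It differs from compound 1 in one place: isopropyl in place of phenyl on an aromatic carbon. Among the measured compounds shown here, the only measured step that touches the same aromatic carbon is a number 28.7 percentage points higher from compound 1 to compound 2 (beyond the scatter), where the phenyl also left and a hydroxy entered. The isopropyl of compound 4 has no donors or acceptors, so that step is only a partial guide; the dimethoxy compound 3 offers no direct comparison. For the measured compounds named here, the one step available points upward from compound 1, and the change to compound 4 again removes the phenyl, so a rise in this assay is expected, of a size at the lower end of what compound 2 showed: a number 15.6 percentage points higher from compound 1 to compound 4 (beyond the scatter). Compound 4 is therefore estimated to give 30%, with a range from 15% to 45%.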

Compound 4, a percentage reported as inhibition, in the whole organism at one dose (the size of the read-out at that dose, not a potency): 19.4%
Estimate against measurement, compound 4: 10.6 percentage points above, and the stated range covers the measured number.
By their numbers in this assay, from the lowest: compounds 1 and 4 (each within the scatter of the next); then compounds 2 and 3 (each within the scatter of the next).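

In this assay, isopropyl can stand in place of phenyl on this aromatic carbon with no readable change (a number 5 percentage points higher from compound 1 to compound 4 (within the scatter)), so losing the phenyl ring does not by itself reproduce the earlier step (a number 28.7 percentage points higher from compound 1 to compound 2 (beyond the scatter)). The hydroxy group is now separated from a second, all-carbon group at the same place (a number 23.7 percentage points lower from compound 2 to compound 4 (beyond the scatter)), and among the three compounds that differ only here, the hydroxy compound alone stands apart, while the phenyl and isopropyl compounds remain within the scatter of each other. No supporting measurement is available to explain this result.

Among the compounds shown here, with only one hydroxy compound at this aromatic carbon, it remains open whether the higher number is particular to hydroxy or would also appear with an amine or a carboxylic acid in the same place. Going by these compounds, it is also open whether a longer carbon chain, such as n-butyl, or a smaller one, such as methyl, would stay level with the phenyl and isopropyl compounds.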